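The source may hold more compounds than are shown below. What is called first, only, known or untested is meant among the compounds shown, and "the series" means these compounds.

Compound 1 `CCCc1nc(C)c2cnnc(SC)n12` and compound 2 `CCCc1nc(C)c2c(C)nnc(SC)n12` share one core. In a functional assay for inhibition, with Homo sapiens as the target (a lower number here means a stronger inhibitor, a higher number a weaker inhibitor), compound 1 reaches only a limit, > 48000 nM. In this assay compound 2 likewise stops at a limit, > 48000 nM. The step that the two limits leave unreadable from compound 1 to compound 2 is therefore not readable, both values sitting at the limit of > 48000 nM in this assay, at which 2 of the 2 values shown sit. Compound 3 `CCCc1nc(C)c2c(C)nnc(S)n12` differs from compound 2 by hydrogen in place of methyl on a sulfur. For the measured compounds named here, no measured step speaks to such a change, and the single step in hand, a step that the two limits leave unreadable from compound 1 to compound 2, gives no size. Compound 3 is expected to remain near the limit, with a step that the limit leaves unreadable from compound 2 to compound 3 of none beyond the scatter. Compound 3 is estimated at 60000 nM, within 20000 nM to 200000 nM.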

Compound 3, half-maximal inhibitory concentration: 45000 nM
Beside the measured number, compound 3's estimate is 1.3-fold (0.12 log units) above it; the range from low to high includes it.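

In this assay, for the compounds shown here, compound 3 gives 45000 nM, the first value that is a number and not a limit. Methylsulfanyl to sulfanyl on this sulfur gives an at least 1.0-fold lower number from compound 2 to compound 3 (0.02 log units; that floor lies within the scatter), so no gain beyond the scatter can be claimed for the change. Its true size stays unreadable because the other partner stands at a limit: the limit of > 48000 nM in this assay, at which 2 of the 3 values shown sit.

Still open, on these data alone, is how a longer chain on the sulfur, such as ethylsulfanyl, or an amine in place of the sulfanyl would read. Also open, as far as these compounds go, is whether any group on the shared core moves the number well clear of the limit.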